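From isopropoxy to hydroxy on compound 2

The compounds below may be only part of what the source reports. "The series", "measured", "known", "first", "only" and "open" are said of these compounds alone.

Compound 1 `COc1c(OC(C)C)cc2occ(-c3csc4ccccc34)c(=O)c2c1OC(C)C` and compound 2 `COc1c(OC(C)C)cc2occ(-c3csc4ccccc34)c(=O)c2c1O` share a core and have both been measured in a functional assay on KB cells (Homo sapiens) for antiproliferative activity, read by sulforhodamine B assay, with a stated time of 72 h; on this read-out lower numbers stand for stronger inhibition and higher numbers for weaker inhibition. Compound 1 gives > 10000 nM, which is a limit of the assay. Compound 2 gives > 10000 nM, which is also a limit, so its standing is known only as a limit. Compound 3 `COc1c(O)cc2occ(-c3csc4ccccc34)c(=O)c2c1O` carries one further change from compound 2: hydrogen in place of isopropyl on an oxygen on an aromatic ring. Among the measured compounds shown here, the only measured step of this kind is a step that the two limits leave unreadable from compound 1 to compound 2, so it offers no size to carry over. For the measured compounds named here, the series so far shows only (the limit of > 10000 nM in this assay, at which 2 of the 2 values shown sit). No step beyond the scatter is therefore expected in this assay, and the expected step is a number no higher from compound 2 to compound 3 (the limit leaves the size open). Compound 3 is estimated at 10000 nM, with an expected range of 4000 nM to 25000 nM.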

Compound 3, half-maximal inhibitory concentration: > 10000 nM
Compound 3: a limit, no number; the forecaster's own chance of this, stated with the estimate: 75%; the middle value lies on the limit itself.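

In this assay compound 3 gives > 10000 nM, which is a limit of the assay. Among the compounds shown here, compound 2 also stands at a limit, so no step between compound 2 and compound 3 can be read. The compounds shown leave open whether isopropoxy to hydroxy changes antiproliferative activity at all.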